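Trimethoxy to dimethoxy on a dienone-triazole-coumarin series

A few compounds are considered here, and "the series" means these few. Any claim that something is new, unique, unknown or untested is made for them only; others in the source may bear on it.

Three compounds of the shared core have a number in a functional assay on THP-1 cells (Homo sapiens) for inhibition, read by sulforhodamine B assay, with a stated time of 48 h, tested at 50 uM; on this read-out lower numbers stand for less inhibition of growth and higher numbers for more inhibition of growth at the one concentration tested. Compound 1 `COc1cc(/C=C/C(=O)/C=C/c2cc(OC)c(OC)c(OC)c2)ccc1OCc1cn(CCCCCOc2cc(=O)oc3ccccc23)nn1` gives 55% and stands second highest of the three. Compound 2 `COc1cc(/C=C/C(=O)/C=C/c2ccccc2)ccc1OCc1cn(CCCCOc2cc(=O)oc3ccccc23)nn1` gives 36%, a number lower than compound 1 by more than the scatter. Compound 3 `COc1cc(/C=C/C(=O)/C=C/c2ccco2)ccc1OCc1cn(CCOc2cc(=O)oc3ccccc23)nn1` gives 78%, the highest number and higher than compound 1 by more than the scatter. The three differ at the aryl end of the dienone and in the chain to the coumarin at once, so no single change among them is isolated.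

Compound 4 `COc1ccc(/C=C/C(=O)/C=C/c2ccc(OCc3cn(CCCCCOc4cc(=O)oc5ccccc45)nn3)c(OC)c2)cc1OC` is not yet measured. It differs from compound 1 in one place: hydrogen in place of methoxy on an aromatic carbon. Cut one bond further out, this reads 3,4,5-trimethoxyphenyl to 3,4-dimethoxyphenyl.

For the measured compounds named here, no measured pair shows this change, so the size of the step is open. The expectation is a step from compound 1 to compound 4 of a number 5 percentage points lower from compound 1 to compound 4 (within the scatter), not clearly beyond the scatter in either direction. Compound 4 is estimated at 50%, with a range from 30% to 70%.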

Compound 4, percent growth inhibition at one concentration: 47%
Compound 4: middle estimate off by 3 percentage points, on the high side, within the range that was stated.
By their numbers in this assay, from the lowest: compound 2; then compounds 4 and 1 (each within the scatter of the next); then compound 3.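

In this assay, hydrogen in place of methoxy on this aromatic carbon, which turns 3,4,5-trimethoxyphenyl into 3,4-dimethoxyphenyl, gives a number 8 percentage points lower from compound 1 to compound 4 (within the scatter). For the compounds shown here, this is the first single change that can be read, since the earlier compounds differ at the aryl end and in the chain to the coumarin at once; here the methoxy group leaves with no step beyond the scatter at the one concentration tested. Nothing on hand gives a reason for this result.

The compounds shown leave open whether an amine or a carboxylic acid on this carbon would stay within the scatter of compound 1. They also leave open whether the same change reads alike on the chain of compound 2 or compound 3.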